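A Methoxy Group on the Benzyl of Compound 2

The source may hold more compounds than are shown below. What is called first, only, known or untested is meant among the compounds shown, and "the series" means these compounds.

Measured in a functional assay on HepG2 cells (Homo sapiens) for inhibition, read by MTT assay, with a stated time of 48 h; a lower number here means a stronger inhibitor, a higher number a weaker inhibitor:
Compound 1 `COc1ccc(-n2c(S)nnc2-c2cc(OC)c(OC)c(OC)c2)cc1`: 57500 nM
Compound 2 `COc1ccc(-n2c(SCc3ccccc3)nnc2-c2cc(OC)c(OC)c(OC)c2)cc1`: > 60000 nM (a limit, not a number)

Compound 2 stands only at a limit, > 60000 nM. Compound 3 `COc1ccc(CSc2nnc(-c3cc(OC)c(OC)c(OC)c3)n2-c2ccc(OC)cc2)cc1` has methoxy in place of hydrogen on an aromatic carbon, para to a large group, turning benzyl into 4-methoxybenzyl: methoxy in place of hydrogen on an aromatic carbon. Within the data shown here, the only measured step that bears on this is an at least 1.0-fold higher number from compound 1 to compound 2 (0.01 log units; that floor lies within the scatter), and it ends on (the limit of > 60000 nM in this assay, at which 1 of the 2 values shown sits). That step adds benzyl in place of hydrogen on a sulfur and shows no shift beyond the scatter, so no step beyond the scatter is expected for compound 3 in this assay. The expected step is a number no higher from compound 2 to compound 3 (the limit leaves the size open). For compound 3 the estimate is 60000 nM, with an expected range from 30000 nM to 120000 nM.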

Compound 3, half-maximal inhibitory concentration: 41100 nM
Estimate against measurement, compound 3: 1.5-fold (0.16 log units) above; the measured number falls inside the stated range.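

Among these compounds, with 4-methoxybenzyl, the sulfur position carries a measured number in this assay for the first time, and methoxy in place of hydrogen on the aromatic carbon gives an at least 1.4-fold lower number from compound 2 to compound 3 (0.16 log units; that floor lies within the scatter). The value of compound 2 is a limit, not a number, so that step gives only a floor: the limit of > 60000 nM in this assay, at which 1 of the 3 values shown sits.
Against hydrogen on the sulfur, 4-methoxybenzyl gives a 1.4-fold lower number from compound 1 to compound 3 (0.15 log units; within the scatter), so the two numbers cannot be told apart. Still open, going by these compounds, is whether an amine or a carboxylic acid on the benzyl ring, or a longer chain in place of benzyl on the sulfur, would give a step beyond the scatter.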